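Swapping chloro for phenyl in an antiproliferative series

The compounds below may be only part of what the source reports. "The series", "measured", "known", "first", "only" and "open" are said of these compounds alone.

In a functional assay on MCF7 cells (Homo sapiens) for antiproliferative activity, read by MTT assay, with a stated time of 72 h (on this read-out lower numbers stand for stronger inhibition and higher numbers for weaker inhibition), compound 1 (`COc1cc(/C=C/c2ccc(C3=C(c4ccc(O)cc4)C4CC(S(=O)(=O)Oc5ccccc5)C3O4)cc2)cc(OC)c1`) is recorded only as a limit, > 100000 nM. Compound 2 (`CCc1ccccc1OS(=O)(=O)C1CC2OC1C(c1ccc(/C=C/c3cc(OC)cc(OC)c3)cc1)=C2c1ccc(O)cc1`) gives 49800 nM, while compound 3 (`O=S(=O)(Oc1ccc(Cl)cc1)C1CC2OC1C(c1ccc(/C=C/c3cc(O)cc(O)c3)cc1)=C2c1ccc(O)cc1`) gives 17900 nM, the lowest number of the set and lower than compound 2 by more than the usual scatter. Compound 4 (`O=S(=O)(Oc1ccc(-c2ccccc2)cc1)C1CC2OC1C(c1ccc(/C=C/c3cc(O)cc(O)c3)cc1)=C2c1ccc(O)cc1`) puts phenyl in place of chloro on an aromatic carbon, para to a large group: phenyl in place of chloro on an aromatic carbon. Among the measured compounds shown here, the only measured step, an at least 2.0-fold lower number from compound 1 to compound 2 (0.30 log units; that floor lies within the scatter), places ethyl in place of hydrogen, a different change, so it offers weak guidance and no clear direction. The expected step is a 1.0-fold higher number from compound 3 to compound 4 (0.00 log units; within the scatter), which means no confident shift beyond the scatter. Compound 4 is estimated at 18000 nM, with an expected range from 6000 nM to 60000 nM.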

Compound 4, half-maximal inhibitory concentration: 7800 nM
Estimate against measurement, compound 4: 2.3-fold (0.36 log units) above; the measured number falls inside the stated range.
By their numbers in this assay, from the lowest: compound 4; then compound 3; then compound 2. At a limit, above all of these: compound 1.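

Going from 4-chlorophenyl to 4-phenylphenyl gives a 2.3-fold lower number from compound 3 to compound 4 (0.36 log units; beyond the scatter) in this assay and so shows that this aromatic carbon, para to a large group, takes a whole phenyl ring in place of chloro with no loss. Among the compounds shown here, this is the first step in the set that lies beyond the scatter. Nothing measured here explains why phenyl gives the lower number. On these data alone, whether an amine or a carboxylic acid on this carbon would lower the number further stays open, as does how far a longer chain would carry the trend.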